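The source may hold more compounds than are shown below. What is called first, only, known or untested is meant among the compounds shown, and "the series" means these compounds.

Two compounds of the shared core have a number in a functional assay on NCI-H460 cells (Homo sapiens) for cytotoxicity, read by MTT assay, with a stated time of 72 h (on this read-out lower numbers stand for stronger inhibition and higher numbers for weaker inhibition), so far. Compound 1 `COc1cc2c(Oc3ccc(NC(=O)c4cn(-c5ccccc5C)nn4)cc3F)ccnc2cc1OCCCN1CCCC1` gives 1260 nM. Compound 2 `COc1cc2c(Oc3ccc(NC(=O)c4cn(-c5ccccc5F)nn4)cc3F)ccnc2cc1OCCCN1CCC(C)CC1` gives 190 nM, the lowest of the two numbers; compound 1 is the only other one, and its number lies beyond the scatter from it, though the two differ in more than one place. Compound 3 `COc1cc2c(Oc3ccc(NC(=O)c4cn(-c5ccccc5C)nn4)cc3F)ccnc2cc1OCCCN1CCC(C)CC1` keeps compound 2 apart from one change: methyl in place of fluoro on an aromatic carbon. Among the compounds with values here, no single-point step between measured compounds is known, so the size is open; the methyl-bearing compound 1 carries the higher number, and a moderate rise beyond the scatter is expected for compound 3, as a 2.2-fold higher number from compound 2 to compound 3 (0.34 log units; beyond the scatter). Compound 3 is estimated at 420 nM, within 150 nM to 1200 nM.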

Compound 3, half-maximal inhibitory concentration: 2730 nM
The estimate for compound 3 lay 6.5-fold (0.81 log units) below the measured number, and the stated range ends below it.
By their numbers in this assay, from the lowest: compound 2; then compound 1; then compound 3.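

Within the data shown here, the aromatic carbon ortho to a large group proves sensitive in this assay: methyl in place of fluoro gives a 14-fold higher number from compound 2 to compound 3 (1.16 log units; beyond the scatter) as the first single-change reading at this place. With the 2-methylphenyl kept, 4-methylpiperidin-1-yl in place of pyrrolidin-1-yl gives a 2.2-fold higher number from compound 1 to compound 3 (0.34 log units; beyond the scatter) as a modest step at the chain end.

Open, going by these compounds, is where chloro, methoxy or plain hydrogen at this aromatic carbon would fall relative to fluoro and methyl, and whether 2-fluorophenyl holds its advantage with pyrrolidin-1-yl at the chain end. No measured evidence bears on the reason for either step.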